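Removing a Bromo Group From Two Related Cores

This account rests on a few compounds, and the source may have more. Where it says the series, first, only, none or still open, it means among the compounds named here.

Four compounds are compared here. Compound 1 `COc1ccc(Cn2cc(/C=N\NC(=O)c3c[nH]c4ccccc34)c3cc(OC)ccc32)cc1` and compound 2 `COc1ccc(Cn2cc(/C=N\NC(=O)c3c[nH]c4ccc(Br)cc34)c3cc(OC)ccc32)cc1` share one core, while compound 3 `COc1ccc(Cn2cc(/C=N\NC(=O)c3c[nH]c4ccc(Br)cc34)c3ccc(F)cc32)cc1` and compound 4 `COc1ccc(Cn2cc(/C=N\NC(=O)c3c[nH]c4ccccc34)c3ccc(F)cc32)cc1` share another; the difference between the two cores is not broken down here.

In a functional assay on DU-145 cells (Homo sapiens) for cytotoxicity (a lower number here means a stronger inhibitor, a higher number a weaker inhibitor), compound 1 gives 19100 nM. In the same assay compound 2 gives 84400 nM, and compound 3 gives 67500 nM. The values of compound 2 and compound 3 lie within the usual scatter of each other, so no order between them can be claimed.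

One structural change is made twice within this set. From compound 2 to compound 1 it is hydrogen in place of bromo on an aromatic carbon, and it brings a 4.4-fold lower number from compound 2 to compound 1 (0.65 log units; beyond the scatter). From compound 3 to compound 4 it is hydrogen in place of bromo on an aromatic carbon. Both times the place of the change is described in exactly the same words, so this is the same change on a different core.

Compound 4 is therefore expected to follow the earlier step: an estimated 4.5-fold lower number from compound 3 to compound 4 (0.65 log units; beyond the scatter), resting on the measured 4.4-fold lower number from compound 2 to compound 1 (0.65 log units; beyond the scatter) and on the value of compound 3. The estimate for compound 4 is 15000 nM, expected to fall between 6000 nM and 40000 nM, with the wider range reflecting that the step has been seen only once before.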

Compound 4, half-maximal inhibitory concentration: 16200 nM
Compound 4: middle estimate off by 1.1-fold (0.03 log units), on the low side; low and high end bracket the measured number.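

Replacing bromo with hydrogen, which turns a 5-bromo-1H-indol-3-yl group into a 1H-indol-3-yl group, gives in this assay a 4.2-fold lower number from compound 3 to compound 4 (0.62 log units; beyond the scatter), and this step matches the one already seen on the other core: the same change on two cores in this assay, a 4.4-fold lower number (0.65 log units; beyond the scatter) from compound 2 to compound 1 and a 4.2-fold lower number (0.62 log units; beyond the scatter) from compound 3 to compound 4, 1.1-fold (0.03 log units) apart, within the scatter of two such steps. Within these four compounds, then, the change carries over from one core to the other with about the same size and in the same direction, so the difference between the two cores does not visibly alter what removing the bromo group does here. Within the data shown here, this does not explain why the number falls, and with only two matched pairs in one cytotoxicity assay on one cell line, it does not establish a rule for other cores or other cells.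

From the compounds shown here alone, only bromo and hydrogen are compared at this place on the ring, so it remains open how a chloro group, an amine or a carboxylic acid in the same position would compare with them. Going by these compounds, it also remains open whether the step would keep its size on a third core, or whether the two cores would keep behaving alike with a larger group at this place.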